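A few compounds are considered here, and "the series" means these few. Any claim that something is new, unique, unknown or untested is made for them only; others in the source may bear on it.

Values so far in an ADME assay on HepG2 cells (Homo sapiens) for inhibition, read by fluorescence and resazurin assay, with a stated time of 72 h (on this read-out higher numbers stand for weaker inhibition and lower numbers for stronger inhibition), are these:
Compound 1 `CS(=O)(=O)Nc1cccc(Nc2nccc(Nc3ccc4nc[nH]c4c3)n2)c1` gives > 25000 nM as a limit
Compound 2 `Cc1cc(Nc2nccc(Nc3ccc4nc[nH]c4c3)n2)ccc1N1CCN(C)CC1` gives 15000 nM as a number
Compound 3 `Cc1cccc(Nc2nccc(Nc3ccc4cn[nH]c4c3)n2)c1` gives 15000 nM as a number

The reading for compound 1 at > 25000 nM is a limit and not a number. Compound 3 stands at 15000 nM in this assay and sits level with compound 2, which gives 15000 nM in the same read-out, the two lying within the usual scatter of each other.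

Compound 4 `Brc1cccc(Nc2nccc(Nc3ccc4cn[nH]c4c3)n2)c1` has not yet been measured. It differs from compound 3 in one place: bromo in place of methyl on an aromatic carbon or, in words, bromo in place of methyl on an aromatic carbon, meta to a large group.

No measured pair among these compounds shows this exchange, so the expectation rests on compound 3 at 15000 nM and on the one-for-one nature of the change. No step beyond the scatter is expected, and no firm direction can be given, though a slight lean towards stronger inhibition is allowed for. The estimated move a 1.3-fold lower number from compound 3 to compound 4 (0.10 log units; within the scatter) is expected to stay within the scatter. For compound 4 the expected value is 12000 nM with an estimated range from 5000 nM to 25000 nM in this assay until the measurement is in.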

Compound 4, half-maximal inhibitory concentration: 17000 nM
Estimate against measurement, compound 4: 1.4-fold (0.15 log units) below; low and high end bracket the measured number.
By their numbers in this assay, from the lowest: compounds 2, 3 and 4 (each within the scatter of the next). At a limit, above all of these: compound 1.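

In this assay, for the compounds shown here, the exchange of methyl for bromo on an aromatic carbon, meta to a large group, gives the first step that can be read in this set: a 1.1-fold higher number from compound 3 to compound 4 (0.05 log units; within the scatter). Until now the compounds differed in more than one place, so their values could only be set side by side; this pair shows that, at this one place, the read-out does not separate a methyl from a bromo, each of which counts one heavy atom and neither of which brings a ring, a charge or a hydrogen-bond donor or acceptor. Compound 1 remains a limit and not a number, so the set still has one entry without a readable value: the limit of > 25000 nM in this assay, at which 1 of the 4 values shown sits.

The compounds shown leave open whether an amine, a carboxylic acid or a longer chain at this place on the ring would give a step beyond the scatter, as only methyl and bromo are compared there. They also leave open whether bromo in place of methyl would read the same on the core of compound 2, as this exchange is seen in a single pair.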